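The source may report more compounds than this note shows. Statements on the series, on what has been measured and on what is new or still open speak of the compounds shown alone.

Measured compounds:
Compound 1 `CC(C)N1C(=O)COc2ccc(-c3cccc(NS(=O)(=O)c4ccc(F)cc4)c3)cc21` — in a functional assay on MCF7 cells (Homo sapiens) for antiproliferative activity, read by MTT assay, with a stated time of 72 h (on this read-out higher numbers stand for weaker inhibition and lower numbers for stronger inhibition), compound 1 gives 26000 nM.
Compound 2 `O=C1COc2ccc(-c3cccc(NS(=O)(=O)c4ccc(F)cc4)c3)cc2N1c1ccccc1` — in this assay compound 2 gives only a limit, > 40000 nM.

Compound 2 stands at the limit of this assay, so its number is not known; the limit of > 40000 nM in this assay, at which 1 of the 2 values shown sits, is where it sits. Among the measured compounds shown here, the single measured step runs from compound 1 to compound 2 as an at least 1.5-fold higher number from compound 1 to compound 2 (0.18 log units; that floor lies within the scatter), and its floor lies within the scatter, so it is weak evidence at best.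

The step to compound 3 `O=C1COc2ccc(-c3cccc(NS(=O)(=O)c4ccc(F)cc4)c3)cc2N1C1CCCCC1` is cyclohexyl in place of phenyl on an amide-type nitrogen in a ring. It touches the same position as the measured step but is not the same change: here the aromatic ring leaves and a six-membered non-aromatic ring of carbon only enters, which brings the substituent closer in kind to the isopropyl of compound 1 than to the phenyl of compound 2. For the measured compounds named here, no measured pair shows this change directly, so the expectation rests on compound 1 giving 26000 nM. It rests as well on compound 2, whose reading is only a limit of the assay.

Compound 3 is therefore expected to return a number near compound 1 in this assay, estimated at 30000 nM with a range of 12000 nM to 80000 nM. The expected step of an at least 1.3-fold lower number from compound 2 to compound 3 (0.12 log units; that floor lies within the scatter) cannot be sized against a limit; a reading again at the limit would not be surprising.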

Compound 3, half-maximal inhibitory concentration: 21400 nM
Beside the measured number, compound 3's estimate is 1.4-fold (0.15 log units) above it; the range from low to high includes it.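

Cyclohexyl on the amide-type nitrogen gives a measurable reading in this assay, where compound 3 gives 21400 nM, and its exchange for isopropyl amounts to a 1.2-fold lower number from compound 1 to compound 3 (0.08 log units; within the scatter), so the two non-aromatic carbon substituents cannot be told apart at this position. The exchange of phenyl for cyclohexyl at the same position gives an at least 1.8-fold lower number from compound 2 to compound 3 (0.27 log units; that floor lies within the scatter), which is only a floor and does not establish that the aromatic ring reads differently from the non-aromatic ring of the same size. Compound 2 remains a limit and not a number, so the true size of this step stays unknown: the limit of > 40000 nM in this assay, at which 1 of the 3 values shown sits.

From the compounds shown here alone, whether any group on this nitrogen can move the reading beyond the scatter stays open, whether a small methyl or a longer chain ending in an amine or a carboxylic acid. The compounds shown also differ only at this one position, so they say nothing about how changes elsewhere on the shared core would affect the reading.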